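Amide reversal on the aryl ring: compound 2 to compound 3

The source may report more compounds than this note shows. Statements on the series, on what has been measured and on what is new or still open speak of the compounds shown alone.

Measured so far:
Compound 1 `C=CC[C@H]1C[C@]2(CCc3ccc(OC)c(OC)c3)OCOC2=CC1=O` gives 2000 nM.
Compound 2 `C=CC[C@H]1C[C@]2([C@@H](C)Cc3ccc(OC)c(C(N)=O)c3)OCOC2=CC1=O` gives 12 nM.

In a functional assay on M14 cells (Homo sapiens) for antiproliferative activity, with a stated time of 72 h (a higher number here means a weaker inhibitor, a lower number a stronger inhibitor), compound 2 holds the lowest of the two numbers; compound 1 sits far above it, beyond the scatter. Compound 3 `C=CC[C@H]1C[C@]2([C@@H](C)Cc3ccc(OC)c(NC(C)=O)c3)OCOC2=CC1=O` differs from compound 2 in one place: acetamido in place of carbamoyl on an aromatic carbon. For the measured compounds named here, no step of this kind has yet been measured, so its size can only be estimated. A modest weakening, or none beyond the scatter, is expected: a 2.5-fold higher number from compound 2 to compound 3 (0.40 log units; beyond the scatter). In this assay compound 3 is expected to give 30 nM, within 8 nM to 120 nM.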

Compound 3, half-maximal inhibitory concentration: 85 nM
Compound 3: middle estimate off by 2.8-fold (0.45 log units), on the low side; low and high end bracket the measured number.
By their numbers in this assay, from the lowest: compound 2; then compound 3; then compound 1.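

In this assay, swapping carbamoyl for acetamido on the aromatic carbon ortho to a methoxy group gives a 7.1-fold higher number from compound 2 to compound 3 (0.85 log units; beyond the scatter). This position therefore tells the two groups apart, although each counts one hydrogen-bond donor and one hydrogen-bond acceptor, and the added heavy atom comes with a real loss. No measurement shown gives a reason for this step.

Open, on these data alone, is how an amine, a carboxylic acid or a longer acyl chain at this carbon would compare with carbamoyl. Also open, as far as these compounds go, is whether the step holds on a different side chain.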